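The source may report more compounds than this note shows. Statements on the series, on what has been measured and on what is new or still open speak of the compounds shown alone.

Measured compounds in an assay on isolated protein for inhibition of Amine oxidase [flavin-containing] B (Homo sapiens); a higher number here means a weaker inhibitor, a lower number a stronger inhibitor:
Compound 1 `CN(C)c1ccc(/C=C/C(=O)c2ccc(N(C)C)cc2O)cc1` gives 12100 nM.
Compound 2 `COc1ccc(/C=C/C(=O)c2ccc(N(C)C)cc2O)cc1` gives 13300 nM.
Compound 3 `CCN(CCCCCCOc1ccc(C(=O)/C=C/c2ccc(N(C)C)cc2)c(O)c1)Cc1ccccc1OC` gives 700 nM.

The measured pair compound 2 and compound 1 carries the change (dimethylamino in place of methoxy on an aromatic carbon), and the step was a 1.1-fold lower number from compound 2 to compound 1 (0.04 log units; within the scatter). Compound 3 differs from compound 2 in more than one place; the difference between the two cores is not broken down here. The values of compound 3 and compound 1 stand far apart, as do those of compound 3 and compound 2.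

Compound 4 `CCN(CCCCCCOc1ccc(C(=O)/C=C/c2ccc(N(C)C)cc2)c(O)c1)Cc1ccccc1N(C)C` is obtained from compound 3 by dimethylamino in place of methoxy on an aromatic carbon. The place is not the same as in the measured pair: there the group is para to a large group, here ortho to a large group, so this is the same kind of change, not the same. A small step is expected, a 1.1-fold lower number from compound 3 to compound 4 (0.03 log units; within the scatter), resting on the measured step of a 1.1-fold lower number from compound 2 to compound 1 (0.04 log units; within the scatter). Compound 4 is therefore estimated at 650 nM, with the range expected from 300 nM to 1500 nM.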

Compound 4, half-maximal inhibitory concentration: 2100 nM
The estimate for compound 4 lay 3.2-fold (0.51 log units) below the measured number, and the stated range ends below it.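

Swapping 2-methoxybenzyl for 2-(dimethylamino)benzyl in this assay gives a 3.0-fold higher number from compound 3 to compound 4 (0.48 log units; beyond the scatter). The change therefore does not carry over at a fixed size from one core to the other: the same change on two cores in this assay, a 1.1-fold lower number (0.04 log units; within the scatter) from compound 2 to compound 1 and a 3.0-fold higher number (0.48 log units; beyond the scatter) from compound 3 to compound 4, 3.3-fold (0.52 log units) apart, beyond the scatter of two such steps

With one pair per core, this does not show whether the gap comes from the place of the group on its ring or from the rest of the core, nor how the change would behave on a third core. Still open, going by these compounds, is how other groups at this place, such as a primary amine, a hydroxyl or a fluorine, compare with the methoxy of compound 3 at 700 nM. Also open, on these data alone, is whether a shorter or longer linking chain alters the size of this step.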